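This account rests on a few compounds, and the source may have more. Where it says the series, first, only, none or still open, it means among the compounds named here.

Measured compounds:
compound 1 `Cc1cccc(N2CCN(C(=O)CN3C(=O)CC(C)(c4ccccc4)C3=O)CC2)c1` gives 100 mg/kg in a functional assay on the whole organism (strain CD-1) with Mus musculus as the target, in the maximal electroshock model, with a stated time of 0.5 h; a lower number here means that less compound is needed, a higher number that more compound is needed for the effect;
compound 2 `CC1(c2ccccc2)CC(=O)N(CC(=O)N2CCN(c3ccc(F)cc3)CC2)C1=O` gives 100 mg/kg in this assay.

Within the data shown here, compound 1 stands level with compound 2, and the one measured step, no change at the digits printed from compound 1 to compound 2 (within the scatter), lies within the scatter. Compound 3 `CC1(c2ccccc2)CC(=O)N(CC(=O)N2CCN(c3ccc(Cl)c(Cl)c3)CC2)C1=O` differs from compound 1 by 3,4-dichlorophenyl in place of 3-methylphenyl on an amine nitrogen in a ring. Among the measured compounds shown here, the only step that bears on this change, from compound 1 to compound 2, exchanged the same ring-bound aryl group without effect, so no step beyond the scatter is expected in this assay for compound 3. The estimate for compound 3 is therefore 100 mg/kg (range 50 mg/kg to 300 mg/kg), an expected step of no change at the digits printed from compound 1 to compound 3 (within the scatter).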

Compound 3, minimum effective dose: "not active" (no number reported)
Compound 3 has no reported number here; the estimate stays without a comparison.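

Among these compounds, compound 3 is reported as not active in this assay, without a number, so no step from compound 1 or compound 2 to compound 3 can be read. The compounds shown leave open how compound 3 would compare numerically with either. No measurement shown accounts for this result.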